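The source may report more compounds than this note shows. Statements on the series, on what has been measured and on what is new or still open speak of the compounds shown alone.

Compound 1 `O=S1(=O)CC(Nc2nonc2/C(=N/O)Nc2ccc(F)c(Br)c2)C1` is the starting point of this comparison. Among the compounds with values here, in an assay on HeLa cells for inhibition of Indoleamine 2,3-dioxygenase 1 (Homo sapiens), read by spectrophotometry, with a stated time of 24 h (on this read-out lower numbers stand for an effect already at smaller amounts and higher numbers for an effect only at larger amounts of compound), compound 1 gives 59 nM, the highest of the two numbers measured so far; its only measured neighbour is compound 2 `CN(C)S(=O)(=O)CCCNc1nonc1/C(=N/O)Nc1ccc(F)c(Br)c1`, which in this assay gives 20 nM, and the step of a 3.0-fold lower number from compound 1 to compound 2 (0.47 log units; beyond the scatter) shows that replacing the ring on that nitrogen with an open chain went together with a modest improvement.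

Compound 3 `NS(=O)(=O)CCONc1nonc1/C(=N/O)Nc1ccc(F)c(Br)c1` has not yet been measured. Relative to compound 1 the change is a group of 7 heavy atoms (2 carbon, 1 nitrogen, 3 oxygen, 1 sulfur; no ring) in place of a group of 6 heavy atoms (3 carbon, 2 oxygen, 1 sulfur; one four-membered non-aromatic ring with 1 hetero atom), on a nitrogen on an aromatic ring. Within the data shown here, the only measured step that bears on this change is the one from compound 1 to compound 2, which also swapped the four-membered ring for an open chain at the same nitrogen and brought a modest gain. The new chain in compound 3 is shorter and carries a hydrogen-bond donor, so the parallel is loose, but a change in the same direction seems more likely than not.

Compound 3 is therefore expected to show a modest step of a 2.0-fold lower number from compound 1 to compound 3 (0.29 log units; within the scatter), giving an estimated 30 nM with a range from 12 nM to 90 nM.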

Compound 3, half-maximal effective concentration: 27 nM
Estimate against measurement, compound 3: 1.1-fold (0.05 log units) above; the measured number falls inside the stated range.
By their numbers in this assay, from the lowest: compounds 2 and 3 (each within the scatter of the next); then compound 1.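

In this assay the step of a 2.2-fold lower number from compound 1 to compound 3 (0.34 log units; beyond the scatter) gives a second case, after compound 2, in which an open chain on this nitrogen goes with a lower number than the four-membered ring of compound 1; no compound shown goes against this. The step of a 1.4-fold higher number from compound 2 to compound 3 (0.13 log units; within the scatter) stays within the scatter, so 2-sulfamoylethoxy and 3-(dimethylsulfamoyl)propyl cannot be told apart here, even though they differ in length, in the oxygen joined to the nitrogen and in the two methyl groups on the sulfonamide nitrogen. No measurement shown here explains the gain seen with either chain or the closeness of the two chains.

Both open chains carry a sulfonamide, so the compounds shown leave open whether the gain comes from opening the ring or from that group, and a plain butyl chain with no sulfur, or a chain ending in a carboxylic acid or an amine, would separate the two. They also leave open how far the chain can grow, which a longer chain of the same type would begin to show, and whether the four-membered ring without its sulfone, as an azetidine, would behave like compound 1.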